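The source may report more compounds than this note shows. Statements on the series, on what has been measured and on what is new or still open speak of the compounds shown alone.

Working notes on a small set sharing one core. Compound 1 `COc1ccc(N(C)c2nc(C)nc3ccccc23)cc1OCCN` gives 343 nM in a functional assay on RKO cells (Homo sapiens) for inhibition, read by MTT assay, with a stated time of 48 h; a lower number here means a stronger inhibitor, a higher number a weaker inhibitor. Compound 2 `COc1ccc(N(C)c2nc(C)nc3ccccc23)cc1C(=O)NCC[Se]C#N` gives 1170 nM, and compound 3 `COc1ccc(N(C)c2nc(C)nc3ccccc23)cc1C(=O)OCCC[Se]C#N` gives 1140 nM. Compound 3 therefore stands second highest of the three numbers, within the scatter of compound 2 and beyond the scatter from compound 1. Compound 4 `COc1ccc(N(C)c2nc(C)nc3ccccc23)cc1OCCCCC[Se]C#N` differs from compound 3 in one place: a group of 9 heavy atoms (6 carbon, 1 nitrogen, 1 oxygen, 1 selenium; no ring) in place of a group of 9 heavy atoms (5 carbon, 1 nitrogen, 2 oxygen, 1 selenium; no ring), on an aromatic carbon. The steps bearing on this are a 3.3-fold higher number from compound 1 to compound 3 (0.52 log units; beyond the scatter) and a 1.0-fold lower number from compound 2 to compound 3 (0.01 log units; within the scatter), which show the two selenium-bearing chains sitting together and above compound 1. Compound 4 keeps a selenium-bearing chain, so the expected step is a 1.3-fold lower number from compound 3 to compound 4 (0.10 log units; within the scatter), nothing beyond the scatter. The estimate for compound 4 is 900 nM, with a range from 400 nM to 2000 nM.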

Compound 4, half-maximal inhibitory concentration: 3560 nM
Estimate against measurement, compound 4: 4.0-fold (0.60 log units) below; measured number above the stated range.
By their numbers in this assay, from the lowest: compound 1; then compounds 3 and 2 (each within the scatter of the next); then compound 4.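

A selenium-bearing chain alone does not set the number at this aromatic carbon: the entering group, which has no carbonyl, does not stay with the two carbonyl-linked chains, giving a 3.1-fold higher number from compound 3 to compound 4 (0.49 log units; beyond the scatter) and a 3.0-fold higher number from compound 2 to compound 4 (0.48 log units; beyond the scatter). Against the amine-ended chain, the change is a 10-fold higher number from compound 1 to compound 4 (1.02 log units; beyond the scatter). No measured evidence accounts for these steps.

From the compounds shown here alone, the carbonyl and the chain change together in the step from compound 3, so their separate contributions remain open. Also open, going by these compounds, is how a shorter chain ending in the same selenium and nitrile group would read.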